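Carbonyl to sulfonyl exchange on the amine nitrogen

The compounds below may be only part of what the source reports. "The series", "measured", "known", "first", "only" and "open" are said of these compounds alone.

Three compounds of the series have been run in an ADME assay on microsomes from liver (Mus musculus) for metabolic stability, read by LC-MS, with NADPH named in the record, with a stated time of 60 min, tested at 1 uM, in the absence of a further agent; a higher number here means that more of the compound is left, a lower number that less of the compound is left. Compound 1 `COc1ccc(-n2c(C)nc3c(N4CC[C@@H](NC(C)=O)C4)nc(C)nc32)cc1OC` returns only a limit of the assay, > 95%. Compound 2 `CC(=O)N[C@@H]1CCN(c2cc(C)nn3c(-c4ccc5cc[nH]c5c4)c(C)nc23)C1` likewise returns a limit in this assay, > 95%. Compound 3 `COc1ccc(-c2c(C)nc3c(N4CC[C@@H](NC(=O)C(F)(F)F)C4)cc(C)nn23)cc1OC` also gives a limit rather than a number, > 95%. Among the compounds with values here, compound 3 therefore stands where all values so far stand, namely at the limit of > 95% in this assay, at which 3 of the 3 values shown sit, and no order among the three can be read from these results. Within the data shown here, no two measured compounds differ in a single place, so no measured step is available to lean on.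

Compound 4 `COc1ccc(-c2c(C)nc3c(N4CC[C@@H](NS(=O)(=O)c5ccc(Cl)cc5)C4)cc(C)nn23)cc1OC` is the next to be measured. Against compound 3 the change is (4-chlorophenyl)sulfonyl in place of (trifluoromethyl)carbonyl on an amine nitrogen. With every measured value sitting at a limit, the step is expected to be a small loss, a number at least 10 percentage points lower from compound 3 to compound 4 (that floor lies within the scatter), not clearly beyond the usual scatter. Compound 4 is estimated to remain largely intact in this assay, at 85%, with a range from 60% to 95%.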

Compound 4, percent of the compound remaining: > 95%
Compound 4: no number, only a limit; the forecaster's own chance of this, stated with the estimate: 40%; middle value at least 10 percentage points from the limit.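

Within the data shown here, no step from compound 3 to compound 4 can be read in this assay, because both values are limits: the limit of > 95% in this assay, at which 4 of the 4 values shown sit. The compounds shown leave open how far (4-chlorophenyl)sulfonyl in place of (trifluoromethyl)carbonyl on the amine nitrogen shifts the percent remaining, and whether any order exists among the four.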